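Aryl replacement on the shared core: compound 4 pending

A few compounds are considered here, and "the series" means these few. Any claim that something is new, unique, unknown or untested is made for them only; others in the source may bear on it.

Measured so far:
compound 1 `COc1ccc(N2CCN(C(=S)SCc3ccc4nc(N)nc(N)c4c3)CC2)cc1`: 1660 nM
compound 2 `Nc1nc(N)c2cc(CSC(=S)N3CCN(c4ccc(Cl)cc4)CC3)ccc2n1`: 6990 nM
compound 3 `CC(=O)c1ccc(N2CCN(C(=S)SCc3ccc4nc(N)nc(N)c4c3)CC2)cc1`: 2040 nM

In a functional assay on HeLa cells (Homo sapiens) for antiproliferative activity, read by MTT assay, with a stated time of 72 h (on this read-out lower numbers stand for stronger inhibition and higher numbers for weaker inhibition), compound 1 holds the lowest of the three numbers; compound 3 lies within the scatter of it, a 1.2-fold higher number from compound 1 to compound 3 (0.09 log units; within the scatter), while compound 2 lies beyond it, a 4.2-fold higher number from compound 1 to compound 2 (0.62 log units; beyond the scatter). Compound 4 `Nc1nc(N)c2cc(CSC(=S)N3CCN(c4ccccc4[N+](=O)[O-])CC3)ccc2n1` differs from compound 1 in one place: 2-nitrophenyl in place of 4-methoxyphenyl on an amine nitrogen in a ring. The two steps that bear on this change both replace the same aryl substituent on the same ring nitrogen, one within the scatter and one a modest rise. Neither introduces 2-nitrophenyl, so the direction for compound 4 is open; a modest rise or no step beyond the scatter is expected. For compound 4 the expected value is 2700 nM (range 1100 nM to 7000 nM), which amounts to an expected step of a 1.6-fold higher number from compound 1 to compound 4 (0.21 log units; within the scatter).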

Compound 4, half-maximal inhibitory concentration: 4880 nM
Compound 4: the middle estimate sits 1.8-fold (0.26 log units) below what was measured; measured number inside the range.
By their numbers in this assay, from the lowest: compounds 1 and 3 (each within the scatter of the next); then compounds 4 and 2 (each within the scatter of the next).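

In this assay, 2-nitrophenyl on the amine nitrogen in the ring gives a 2.9-fold higher number from compound 1 to compound 4 (0.47 log units; beyond the scatter) and a 2.4-fold higher number from compound 3 to compound 4 (0.38 log units; beyond the scatter), while a 1.4-fold lower number from compound 2 to compound 4 (0.16 log units; within the scatter) keeps compound 4 within the scatter of compound 2. For the compounds shown here, a second aryl group thus joins 4-chlorophenyl on the weaker side of compound 1 and compound 3, though no step at this position exceeds a modest size. Nothing measured for these compounds accounts for the differences between the aryl groups.

Open, as far as these compounds go, is whether the rise follows the nitro group or its place on the phenyl ring, a question 4-nitrophenyl would address. Also open, from the compounds shown here alone, is how an amine or a carboxylic acid on that ring would read here.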